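The compounds below may be only part of what the source reports. "The series", "measured", "known", "first", "only" and "open" are said of these compounds alone.

Measured in a functional assay on HeLa cells (Homo sapiens) for antiproliferative activity, read by sulforhodamine B assay, with a stated time of 48 h; a higher number here means a weaker inhibitor of growth, a lower number a stronger inhibitor of growth:

- compound 1 `COc1ccc(Cn2cc(CNC(=O)c3cn(-c4ccccc4)nc3-c3ccc(F)cc3)nn2)cc1OC`: 200 nM
- compound 2 `COc1ccc(-c2nn(-c3ccccc3)cc2C(=O)NCc2cn(Cc3ccc(C(F)(F)F)cc3)nn2)cc1`: 6200 nM
- compound 3 `COc1ccc(Cn2cc(CNC(=O)c3cn(-c4ccccc4)nc3-c3ccc(OC)cc3)nn2)cc1`: 450 nM

Compound 3 stands second highest of the three numbers. Its nearest neighbour is compound 1, with a lower number; its furthest is compound 2, with a much higher one.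

Compound 4 `COc1ccc(-c2nn(-c3ccccc3)cc2C(=O)NCc2cn(Cc3ccc(OC)c(OC)c3)nn2)cc1` differs from compound 3 by methoxy in place of hydrogen on an aromatic carbon; in the wider reading, 4-methoxybenzyl becomes 3,4-dimethoxybenzyl. For the measured compounds named here, only one measured step touches that benzyl ring, a 14-fold lower number from compound 2 to compound 3 (1.14 log units; beyond the scatter), and it shows that a change of substituent on this ring can move this assay a long way. Going by the values given here, compound 1 already carries the 3,4-dimethoxybenzyl, but it also differs from compound 3 on the other aryl ring, so no single step connects them; its value shows only that the 3,4-dimethoxybenzyl is compatible with the lowest number in the set.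

The change is therefore expected to give a small lowering, near the edge of the scatter. Compound 4 is estimated at 280 nM in this assay, with a range from 110 nM to 700 nM, corresponding to an expected step of a 1.6-fold lower number from compound 3 to compound 4 (0.21 log units; within the scatter).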

Compound 4, concentration for 50% growth inhibition: 800 nM
Compound 4: the middle estimate sits 2.9-fold (0.46 log units) below what was measured; the measured number lies above the stated range.
By their numbers in this assay, from the lowest: compound 1; then compounds 3 and 4 (each within the scatter of the next); then compound 2.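

In this assay, a second methoxy on the benzyl ring, ortho to a methoxy group, gives a 1.8-fold higher number from compound 3 to compound 4 (0.25 log units; within the scatter) and so does not separate 4-methoxybenzyl from 3,4-dimethoxybenzyl, while a 7.8-fold lower number from compound 2 to compound 4 (0.89 log units; beyond the scatter) shows that the 4-(trifluoromethyl)benzyl compound stays apart from the dimethoxy one as well as from the monomethoxy one. The other aryl ring now has its first single-place reading: with 3,4-dimethoxybenzyl held fixed, methoxy in place of fluoro gives a 4.0-fold higher number from compound 1 to compound 4 (0.60 log units; beyond the scatter) in this assay, so the low number of compound 1 goes with the fluoro and not with the extra benzyl methoxy. No measurement on hand gives a reason for any of these steps.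

Still open, from the compounds shown here alone, is whether the fluoro keeps its advantage with 4-methoxybenzyl or with other benzyl substituents, since its reading rests on a single pair of compounds. Also open, going by these compounds, is how the benzyl ring responds to a group of another kind, such as an amine or a carboxylic acid, in place of methoxy.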